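This account rests on a few compounds, and the source may have more. Where it says the series, first, only, none or still open, it means among the compounds named here.

Measured compounds:
compound 1 `CC(C)(C)N(NC(=O)c1ccccc1)C(=O)c1ccccc1F` — in an assay on cells for agonist activity at ecdysone receptor (Bombyx mori), read by a luciferase reporter, with a stated time of 24 h (on this read-out higher numbers stand for an effect only at larger amounts of compound and lower numbers for an effect already at smaller amounts), compound 1 gives 309 nM
compound 2 `CCc1ccccc1C(=O)N(NC(=O)c1ccccc1)C(C)(C)C` — in this assay compound 2 gives 589 nM
compound 3 `CC(C)(C)N(NC(=O)c1ccccc1I)C(=O)c1ccccc1Cl` — in this assay compound 3 gives 1290 nM

Among these three numbers compound 3 stands highest; its nearest neighbour is compound 2, and the gap to compound 1 is larger still, both beyond the scatter. Within the data shown here, the only single-place step in the set is a 1.9-fold higher number from compound 1 to compound 2 (0.28 log units; within the scatter), which concerns the ring on the other carbonyl and is within the scatter.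

Compound 4 `CC(C)(C)N(NC(=O)c1ccc(C#N)cc1)C(=O)c1ccccc1Cl` differs from compound 3 in the following way: 4-cyanophenyl in place of 2-iodophenyl on a carbonyl carbon. Among the measured compounds shown here, no measured step bears on this change directly. Compounds 1 and 2, which carry an unsubstituted phenyl on that carbonyl carbon, show lower numbers than compound 3, so a modest step towards a lower number in this assay is expected, with wide uncertainty. For compound 4 the expected value in this assay is 700 nM, with a range from 250 nM to 2500 nM. The step that estimate means for compound 4 is expected to be a 1.8-fold lower number from compound 3 to compound 4 (0.27 log units; within the scatter).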

Compound 4, half-maximal effective concentration: 603 nM
Estimate against measurement, compound 4: 1.2-fold (0.06 log units) above; measured number inside the range.
By their numbers in this assay, from the lowest: compounds 1, 2 and 4 (each within the scatter of the next); then compound 3.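

In this assay, among these compounds, placing 4-cyanophenyl in place of 2-iodophenyl on a carbonyl carbon gives a 2.1-fold lower number from compound 3 to compound 4 (0.33 log units; beyond the scatter), a modest change and the first single-place reading at this position, as the earlier step concerned the ring on the other carbonyl. Since the two groups differ both in their substituent and in the number in their names, this one step cannot separate the change from iodine to nitrile from the change in where the substituent sits. No measurement available here accounts for the step.

The compounds shown leave open how 2-cyanophenyl or 4-iodophenyl on this carbonyl carbon would read, which would divide the step into those two parts. They also leave open how a ring bearing an amine or a carboxylic acid would behave there.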